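The source may hold more compounds than are shown below. What is called first, only, known or untested is meant among the compounds shown, and "the series" means these compounds.

Working notes on the series, read in a functional assay on HeLa cells (Homo sapiens) for antiproliferative activity, read by MTT assay, with a stated time of 48 h; on this read-out higher numbers stand for weaker inhibition of growth and lower numbers for stronger inhibition of growth. Compound 1 (`COC(=O)N1N=C(c2cccc(OC)c2)CC1c1cc(OC)c(OC)c(OC)c1`) gives 1530 nM, and compound 2 (`CCOc1cccc(C2=NN(C(=O)OC)C(c3cc(OC)c(OC)c(OC)c3)C2)c1`) gives 4970 nM. Compound 3 (`COC(=O)N1N=C(c2cccc(Cl)c2)CC1c1cc(OC)c(OC)c(OC)c1`) gives 160 nM, the lowest of the three numbers, so compound 3 is the strongest inhibitor of growth measured so far.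

The next compound is compound 4 (`COC(=O)N1N=C(c2ccc(O)cc2)CC1c1cc(OC)c(OC)c(OC)c1`). It keeps the shared core and differs from compound 3 in one place: 4-hydroxyphenyl in place of 3-chlorophenyl on a carbon with a double bond to nitrogen. Here, 4-hydroxyphenyl stands in place of 3-chlorophenyl on a carbon with a double bond to nitrogen.

Among the compounds with values here, three measured steps bear on this change. Chloro in place of methoxy gave a 9.6-fold lower number from compound 1 to compound 3 (0.98 log units; beyond the scatter), a modest step, and chloro in place of ethoxy gave a 31-fold lower number from compound 2 to compound 3 (1.49 log units; beyond the scatter), a large one. Between the two oxygen-bearing compounds, the step was a 3.2-fold higher number from compound 1 to compound 2 (0.51 log units; beyond the scatter), also modest. Both steps that remove chloro from compound 3 would therefore run towards a higher number. Within the data shown here, no measured compound carries 4-hydroxyphenyl, so these steps are only a guide.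

A modest to large rise is expected in this assay, and the expected step is an 11-fold higher number from compound 3 to compound 4 (1.05 log units; beyond the scatter). Compound 4 is estimated at 1800 nM, with an expected range of 350 nM to 8000 nM.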

Compound 4, concentration for 50% growth inhibition: 1140 nM
The estimate for compound 4 lay 1.6-fold (0.20 log units) above the measured number; low and high end bracket the measured number.
By their numbers in this assay, from the lowest: compound 3; then compounds 4 and 1 (each within the scatter of the next); then compound 2.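

The 4-hydroxyphenyl group on this carbon with a double bond to nitrogen does not match 3-chlorophenyl, with a 7.1-fold higher number from compound 3 to compound 4 (0.85 log units; beyond the scatter) in this assay, and compound 3 remains the strongest inhibitor of growth of the four. Set against 3-methoxyphenyl, the same group gives a 1.3-fold lower number from compound 1 to compound 4 (0.13 log units; within the scatter), so the two cannot be told apart here, while against 3-ethoxyphenyl it gives a 4.4-fold lower number from compound 2 to compound 4 (0.64 log units; beyond the scatter), which leaves 3-ethoxyphenyl alone at the weak end among the three oxygen-bearing groups. The data at hand offer no measured explanation for these differences.

Compound 4 differs from the other compounds in both the group and where it stands on the phenyl ring, so the effects of these two features remain unseparated; 3-hydroxyphenyl and 4-chlorophenyl would pull them apart. Also open, going by these compounds, is how an amine or a carboxylic acid on the same phenyl ring would compare with the chloro group of compound 3.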